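Epimer of a Diterpenoid Ester: Expected Cytotoxicity

This account rests on a few compounds, and the source may have more. Where it says the series, first, only, none or still open, it means among the compounds named here.

Measured compounds:
compound 1 `COc1ccc(C(=O)OCC2=CC[C@@]3(C)CCC(C(C)C)=C3CC2)cc1` – 25600 nM
compound 2 `COc1ccc(C(=O)O[C@H]2CC(C)=C[C@H](O)[C@@]3(C)[C@@H](OC(C)=O)C[C@@](O)(C(C)C)[C@H]23)cc1` – 5900 nM

In a functional assay on Jurkat cells (Homo sapiens) for cytotoxicity, read by MTT assay, with a stated time of 72 h (on this read-out lower numbers stand for stronger inhibition and higher numbers for weaker inhibition), compound 1 gives 25600 nM, while compound 2 gives 5900 nM. Compound 2 therefore stands at the lowest number of the two measured values, and the gap to compound 1 lies beyond the scatter, so compound 2 is the more potent of the pair in this assay. Among the compounds with values here, no pair of measured compounds differs in one place only, so no single-step comparison can be drawn between them.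

Compound 3 `COc1ccc(C(=O)O[C@H]2CC(C)=C[C@@H](O)[C@@]3(C)[C@@H](OC(C)=O)C[C@@](O)(C(C)C)[C@H]23)cc1` is the unmeasured compound. It differs from compound 2 as follows: the two compounds have the same atoms and bonds and differ only in configuration as drawn: 1 of 6 stereo elements differ; a stereocentre at a saturated ring carbon is drawn S in compound 2 and R in compound 3. The two measured values give no guidance on how a change of configuration alone moves this assay. A modest shift in either direction is plausible, but none beyond the scatter is expected; the step from compound 2 to compound 3 is estimated as a 1.2-fold higher number from compound 2 to compound 3 (0.07 log units; within the scatter). On that basis compound 3 is estimated at 7000 nM, within a range from 2000 nM to 25000 nM in this assay.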

Compound 3, half-maximal inhibitory concentration: 33600 nM
Compound 3: middle estimate off by 4.8-fold (0.68 log units), on the low side, and the stated range ends below it.
By their numbers in this assay, from the lowest: compound 2; then compounds 1 and 3 (each within the scatter of the next).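

In this assay, the configuration at this saturated ring carbon proves to matter: redrawing the stereocentre from S to R gives a 5.7-fold higher number from compound 2 to compound 3 (0.76 log units; beyond the scatter), a step beyond the scatter and thus a clear loss of inhibition. Within the data shown here, the earlier compounds could not show this, since no measured pair differed in one place only, so this is the first single change that can be read on its own, and of the two configurations, the S form gives the stronger inhibition. With atoms and bonds unchanged and the other stereo elements drawn alike, the whole step can be assigned to this one stereocentre, and the basis for that assignment is: the fact that compounds 2 and 3 differ only in the configuration as drawn

The compounds shown do not tell how the step arises, nor whether the other stereo elements of the shared core are as sensitive as this one. They also leave open whether this ring carbon would accept a different substituent, such as an amine or a methyl ether, and whether the preference for the S form would hold with such a group in place.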